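Phenyl for vinyl on the chain of compound 1

This account rests on a few compounds, and the source may have more. Where it says the series, first, only, none or still open, it means among the compounds named here.

Among the measured compounds shown here, in a functional assay on BV-2 cells (Mus musculus) for inhibition, read by Griess assay, with a stated time of 24 h (on this read-out lower numbers stand for stronger inhibition and higher numbers for weaker inhibition), compound 1 `C=CCn1ccc(-c2cc(Br)ccc2O)n1` gives 112000 nM, the only actual number available for this small set. Compound 2 `Oc1ccc(Br)cc1-c1ccn(-c2ccccc2)n1` gives > 200000 nM, which is a limit of the assay and not a number. For the measured compounds named here, the one measured step is an at least 1.7-fold higher number from compound 1 to compound 2 (0.25 log units; that floor lies within the scatter). That step replaces allyl with phenyl on an aromatic nitrogen, so it bears on the next change only loosely.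

Compound 3 `Oc1ccc(Br)cc1-c1ccn(Cc2ccccc2)n1` departs from compound 1 by a different change: phenyl in place of vinyl on a saturated chain carbon bound to an aromatic nitrogen. Here phenyl takes the place of vinyl, and the saturated chain carbon bound to the aromatic nitrogen remains. Going by the values given here, the measured step, an at least 1.7-fold higher number from compound 1 to compound 2 (0.25 log units; that floor lies within the scatter), is the only guide, and it sets no firm direction, so no change beyond the scatter is expected in this assay. The estimated step is a 1.1-fold lower number from compound 1 to compound 3 (0.05 log units; within the scatter). For compound 3 the expected value is 100000 nM, with an estimated range of 40000 nM to 200000 nM. A reading that gives only a limit remains possible.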

Compound 3, half-maximal inhibitory concentration: > 200000 nM
Compound 3: a limit, no number (the forecaster's own chance of this, stated with the estimate: 30%); middle value at least 2.0-fold (0.30 log units) away from the limit.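

Phenyl in place of vinyl on a saturated chain carbon bound to an aromatic nitrogen gives an at least 1.7-fold higher number from compound 1 to compound 3 (0.25 log units; that floor lies within the scatter) in this assay. Compound 3 gives > 200000 nM, which is a limit of the assay and not a number. The earlier compounds showed this outcome only for phenyl set directly on the aromatic nitrogen in compound 2; it now also holds with the saturated chain carbon kept, so both compounds with phenyl end at the same limit, the read-out cannot separate them, and the step from compound 1 has only a floor: the limit of > 200000 nM in this assay, at which 2 of the 3 values shown sit.

As far as these compounds go, that floor lies within the scatter and neither compound with phenyl has an actual value, so whether phenyl moves the number at all stays open. Also open, from the compounds shown here alone, is how this assay would read with an amine, a carboxylic acid or a longer chain in place of vinyl on the same saturated chain carbon, and whether any of these would give a lower number than compound 1 does.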